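Shortening the Chain: Expected Half-Life of Compound 3

A few compounds are considered here, and "the series" means these few. Any claim that something is new, unique, unknown or untested is made for them only; others in the source may bear on it.

Compound 1 `C/C(=N/c1ccnc2cc(Cl)ccc12)NCCCCN1CCCCC1`: > 1 h
Compound 2 `Clc1ccc2c(N(CCCN3CCCCC3)/C(=N/CCCN3CCCCC3)c3ccccc3)ccnc2c1`: 0.517 h

In an ADME assay (liver) for metabolic stability, with Liver microsome (Homo sapiens) as the target, read by LC-MS, using microsomes, tested at 1 uM (a higher number here means that the compound lasts longer, a lower number that the compound disappears faster), compound 1 gives > 1 h, which is a limit of the assay rather than a number. Compound 2 gives 0.517 h in this assay. Compound 1 therefore stands at the limit: the limit of > 1 h in this assay, at which 1 of the 2 values shown sits. Compound 3 `C/C(=N/c1ccnc2cc(Cl)ccc12)NCCCN1CCCCC1` differs from compound 1 by piperidin-1-yl in place of (piperidin-1-yl)methyl on a saturated chain carbon, three bonds along the chain from an amine nitrogen. Among the compounds with values here, no measured pair shows this change, so for compound 3 the step is expected to stay within the scatter, with no clear direction: a step that the limit leaves unreadable from compound 1 to compound 3. Compound 3 is thus estimated at 1.5 h in this assay, within a range from 0.6 h to 4 h.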

Compound 3, half-life: > 1 h
Compound 3: only a limit was reported; the forecaster's own chance of this, stated with the estimate: 60%; the middle value does not contradict the limit.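

No step from compound 1 to compound 3 can be read, as both results are limits rather than numbers: the limit of > 1 h in this assay, at which 2 of the 3 values shown sit.

On these data alone, how far compound 1 and compound 3 lie past that limit in this assay, and so what shortening the chain does, stays open.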